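One More Carbon on the Amine Chain

A few compounds are considered here, and "the series" means these few. Any claim that something is new, unique, unknown or untested is made for them only; others in the source may bear on it.

Compound 1 (`CCCNC(=C\C(=O)/C=C/c1ccc(O)c(OC)c1)/C=C/c1ccc(O)c(OC)c1`) carries a propyl chain. In a functional assay on HT-29 cells (Homo sapiens) for inhibition, read by sulforhodamine B assay, with a stated time of 72 h (on this read-out lower numbers stand for stronger inhibition and higher numbers for weaker inhibition), compound 1 gives > 25000 nM, which is a limit and not a number. The nearest actual number comes from compound 2 (`CC(=O)Oc1ccc(/C=C/C(=O)/C=C(/C=C/c2ccc(OC(C)=O)cc2)NCC(C)C)cc1`), which gives 22600 nM. Compound 3 (`CCCCNC(=C\C(=O)/C=C/c1ccc(O)c(OC)c1)/C=C/c1ccc(O)c(OC)c1`) lengthens the chain from propyl to butyl (methyl in place of hydrogen on a saturated chain carbon, three bonds along the chain from an amine nitrogen). Going by the values given here, no measured pair shows what such a change does in this assay, so only a small shift towards stronger inhibition, within the usual scatter, is expected. The expected change is an at least 1.2-fold lower number from compound 1 to compound 3 (0.09 log units; that floor lies within the scatter). For compound 3 the estimate is 20000 nM, with an expected range of 9000 nM to 40000 nM.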

Compound 3, half-maximal inhibitory concentration: 21200 nM
Compound 3: the middle estimate sits 1.1-fold (0.03 log units) below what was measured; the range from low to high includes it.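

In this assay compound 3 gives a measured number on the amine chain where compound 1 gives only a limit. Going by these compounds alone, this yields the first reading for adding methyl in place of hydrogen at this chain carbon: an at least 1.1-fold lower number from compound 1 to compound 3 (0.07 log units; that floor lies within the scatter). That reading is only a floor, and the real size of the step stays unknown, because compound 1 sits at a limit of the assay: the limit of > 25000 nM in this assay, at which 1 of the 3 values shown sits.

Still open, as far as these compounds go, is whether a longer chain, such as pentyl or hexyl, would move the number beyond the scatter. A chain ending in an amine or a carboxylic acid is equally untested among the compounds shown.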